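Replacing a Benzyl(ethyl)amino Group with Piperidin-1-yl

The compounds below may be only part of what the source reports. "The series", "measured", "known", "first", "only" and "open" are said of these compounds alone.

Among the measured compounds shown here, in an assay on cells for inhibition of Amine oxidase [flavin-containing] A (Homo sapiens), read by fluorescence, with a stated time of 30 min, tested at 10 uM (on this read-out higher numbers stand for more inhibition at the one concentration tested (going by the name of the read-out) and lower numbers for less inhibition), compound 1 `CCN(Cc1ccccc1)Cc1ccc(/C=C2\Oc3cc(OC)c(OC)cc3C2=O)cc1O` gives 17% and stands highest of the two numbers so far, with compound 2 `COc1cc2c(cc1OC)C(=O)/C(=C/c1ccc(CN3CCN(Cc4ccccc4)CC3)c(O)c1)O2` giving 15.3% in this assay, a gap within the scatter. For the measured compounds named here, no step between measured compounds is known. Compound 3 `COc1cc2c(cc1OC)C(=O)/C(=C/c1ccc(CN3CCCCC3)c(O)c1)O2` differs from compound 1 by piperidin-1-yl in place of benzyl(ethyl)amino on a saturated chain carbon bound to an aromatic carbon. With nothing beyond a single pair of similar numbers to build on, the step from compound 1 to compound 3 in this assay is expected to be small, a number 3 percentage points lower from compound 1 to compound 3 (within the scatter), and not beyond the scatter. Compound 3 is therefore estimated at 14%, within a range from 4% to 25%.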

Compound 3, a percentage reported as inhibition, at one concentration (the size of the read-out at that concentration, not a potency): 15.3%
Compound 3: middle estimate off by 1.3 percentage points, on the low side; the measured number falls inside the stated range.
By their numbers in this assay, from the lowest: compounds 2, 3 and 1 (each within the scatter of the next).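

Among the compounds shown here, the step of a number 1.7 percentage points lower from compound 1 to compound 3 (within the scatter) in this assay stays within the scatter, and it is the first step that can be read at this place. On a saturated chain carbon bound to an aromatic carbon, piperidin-1-yl and benzyl(ethyl)amino therefore cannot be told apart here, although the entering group has fewer heavy atoms and lacks the six-membered aromatic ring of carbon only. Nothing available explains this result.

On these data alone, whether morpholin-4-yl, dimethylamino or a carboxylic acid at this place would give a step beyond the scatter remains open.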